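The compounds below may be only part of what the source reports. "The series", "measured", "known", "first", "only" and "open" are said of these compounds alone.

The measured compounds are:

Compound 1, `CCCCCC/C=C/C[C@H]1C[C@@H]([C@@H](O)c2ccccc2)CO[C@@H]1c1ccccc1`: 4990 nM
Compound 2, `COc1ccc(/C=C/C[C@H]2C[C@@H]([C@@H](O)c3ccccc3)CO[C@@H]2c2ccccc2)cc1`: 9010 nM
Compound 3, `COc1ccc(/C=C/C[C@@H]2C[C@H]([C@H](O)c3ccc(OC)c(OC)c3)CO[C@H]2c2ccc(OC)c(OC)c2)cc1OC`: "not determined" (no result reported)

These numbers come from a functional assay on HL-60 cells (Homo sapiens) for cytotoxicity, read by WST assay, with a stated time of 48 h; a lower number here means a stronger inhibitor, a higher number a weaker inhibitor. Among the compounds with values here, compound 2 gives the highest of the two numbers, and its only neighbour is compound 1, which differs at one place: the step of a 1.8-fold higher number from compound 1 to compound 2 (0.26 log units; within the scatter) is within the scatter, so the two compounds cannot be told apart on these numbers. Compound 3 carries several methoxy groups on its rings but has no value, so it adds nothing to the comparison.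

Compound 4, `O[C@@H](c1ccccc1)[C@H]1CO[C@H](c2ccccc2)[C@@H](C/C=C/c2ccccc2F)C1`, has not been measured. It differs from compound 2 in one place: 2-fluorophenyl in place of 4-methoxyphenyl on a double-bonded chain carbon bound to a double-bonded chain carbon. Within the data shown here, the one measured step that bears on this change is the one from compound 1 to compound 2, where the group at the same place was exchanged and the number moved only within the scatter. On that basis the change to compound 4 is expected to give no step beyond the scatter, a 1.3-fold lower number from compound 2 to compound 4 (0.11 log units; within the scatter), in either direction. For compound 4 in this assay the estimate is therefore 7000 nM, with a range from 2500 nM to 20000 nM.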

Compound 4, half-maximal inhibitory concentration: 9530 nM
Estimate against measurement, compound 4: 1.4-fold (0.13 log units) below; low and high end bracket the measured number.
By their numbers in this assay, from the lowest: compounds 1, 2 and 4 (each within the scatter of the next).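

In this assay, three different groups have now been compared at this place, on a double-bonded chain carbon bound to a double-bonded chain carbon. Both new comparisons, a 1.1-fold higher number from compound 2 to compound 4 (0.02 log units; within the scatter) and a 1.9-fold higher number from compound 1 to compound 4 (0.28 log units; within the scatter), lie within the scatter, so 2-fluorophenyl cannot be told apart from either 4-methoxyphenyl or hexyl on these numbers, whereas the earlier single step compared only the last two groups. Swapping an oxygen-bearing ring for a fluorine-bearing ring, or an open carbon chain for a ring, therefore gives no readable difference among these three compounds, and no measurement is available to explain this result.

The compounds shown leave open whether any other group at this place would give a step beyond the scatter, for example a primary amine, a carboxylic acid or a much longer carbon chain. They also leave open whether changes elsewhere on the shared core, such as on the two phenyl groups that compounds 1, 2 and 4 have in common, would matter more than changes at this place.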